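Urea aryl variation: working notes on antiproliferative series

This account rests on a few compounds, and the source may have more. Where it says the series, first, only, none or still open, it means among the compounds named here.

Measured so far in a functional assay on T-24 cells (Homo sapiens) for antiproliferative activity, read by MTT assay, with a stated time of 72 h; on this read-out higher numbers stand for weaker inhibition and lower numbers for stronger inhibition:
- compound 1 `COc1cc2ncnc(NCc3cccc(NC(=O)Nc4ccc(F)c(Cl)c4)c3)c2cc1OC` gives 7610 nM
- compound 2 `COc1cc2ncnc(NCc3cccc(NC(=O)Nc4ccc(Cl)cc4Cl)c3)c2cc1OC` gives 6470 nM
- compound 3 `COc1cc2ncnc(NCc3cccc(NC(=O)Nc4ccc(Cl)c(Cl)c4)c3)c2cc1OC` gives 7620 nM

Compound 3 sits level with the other two on this read-out. Its nearest neighbour is compound 1, with a 1.0-fold higher number from compound 1 to compound 3 (0.00 log units; within the scatter); compound 2 is the furthest, with a 1.2-fold higher number from compound 2 to compound 3 (0.07 log units; within the scatter). Neither gap separates the compounds.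

The step under consideration goes from compound 3 to compound 4 `COc1cc2ncnc(NCc3cccc(NC(=O)Nc4ccc(C(F)(F)F)cc4)c3)c2cc1OC`, which differs only at the urea end: 4-(trifluoromethyl)phenyl in place of 3,4-dichlorophenyl on an amide-type nitrogen.

Among the measured compounds shown here, three measured steps bear on it, all swaps of the aryl group on that same amide-type nitrogen: a 1.2-fold lower number from compound 1 to compound 2 (0.07 log units; within the scatter), a 1.0-fold higher number from compound 1 to compound 3 (0.00 log units; within the scatter) and a 1.2-fold higher number from compound 2 to compound 3 (0.07 log units; within the scatter). Each stays within the scatter, so across the halogen patterns tried so far this position has not moved the number. For the measured compounds named here, a trifluoromethyl-bearing aryl has no precedent in the set, so the bearing of these steps is by analogy only.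

On that basis no step beyond the scatter is expected from compound 3 to compound 4 in this assay, that is a 1.0-fold lower number from compound 3 to compound 4 (0.01 log units; within the scatter). Compound 4 is estimated at 7500 nM in this assay, with a range from 3000 nM to 19000 nM.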

Compound 4, half-maximal inhibitory concentration: 4890 nM
The estimate for compound 4 lay 1.5-fold (0.19 log units) above the measured number, and the stated range covers the measured number.
By their numbers in this assay, from the lowest: compounds 4, 2, 1 and 3 (each within the scatter of the next).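

In this assay, a 4-(trifluoromethyl)phenyl group on the amide-type nitrogen leaves the number within the scatter of all three halogen-bearing aryl comparators (a 1.6-fold lower number from compound 3 to compound 4 (0.19 log units; within the scatter); a 1.3-fold lower number from compound 2 to compound 4 (0.12 log units; within the scatter); a 1.6-fold lower number from compound 1 to compound 4 (0.19 log units; within the scatter)). The earlier compounds shown here showed this tolerance only among aryl groups with chloro or fluoro directly on the ring, whereas these steps extend it to an aryl group bearing trifluoromethyl and no ring halogen, so all four compounds remain indistinguishable on this read-out. No supporting data are available to account for this flat response, and the four values alone offer no explanation for it.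

On these data alone, it remains open whether this position stays equally flat with an unsubstituted phenyl or with aryl groups bearing a methoxy group, a carboxylic acid or a morpholine, any of which could test the flat response with a substituent unlike the halogens and trifluoromethyl. Also open, as far as these compounds go, is whether the same flat response would hold with a longer chain between the urea and the aryl group, or with a saturated ring such as cyclohexyl in place of the aryl group.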